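A few compounds are considered here, and "the series" means these few. Any claim that something is new, unique, unknown or untested is made for them only; others in the source may bear on it.

Three compounds share one core and differ only in the group on the saturated chain carbon bound to an oxygen on an aromatic ring; all three were tested in a functional assay on A-375 cells (Homo sapiens) for antiproliferative activity, read by MTT assay, with a stated time of 24 h; on this read-out lower numbers stand for stronger inhibition and higher numbers for weaker inhibition:

Compound 1 `C=CCOc1ccc2c(=O)c(-c3cc(OC)c(OC)cc3OC)coc2c1` gives 4750 nM.
Compound 2 `COc1cc(OC)c(-c2coc3cc(OCc4ccccc4)ccc3c2=O)cc1OC` gives 1640 nM.
Compound 3 `COc1cc(OC)c(-c2coc3cc(OCc4ccccc4C)ccc3c2=O)cc1OC` gives 1360 nM.

Compound 2 stands second highest of these three numbers. Its nearest neighbour is reached by a 1.2-fold lower number from compound 2 to compound 3 (0.08 log units; within the scatter), a step that stays within the usual scatter of such measurements, so the two numbers cannot be told apart with confidence. Its furthest neighbour lies at the other end of a 2.9-fold lower number from compound 1 to compound 2 (0.46 log units; beyond the scatter), a modest step beyond the scatter; the related step of a 3.5-fold lower number from compound 1 to compound 3 (0.54 log units; beyond the scatter) is of the same modest size.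

Compound 4 `COc1cc(OC)c(-c2coc3cc(OCc4ccccc4Cl)ccc3c2=O)cc1OC` is the next compound. It differs from compound 2 by chloro in place of hydrogen on an aromatic carbon. For the measured compounds named here, only one measured step touches the same position with the same kind of change, the exchange of hydrogen for methyl on the aromatic carbon from compound 2 to compound 3, and that step was within the scatter. On this basis no step beyond the scatter is expected for compound 4 in this assay: the expected move is a 1.2-fold lower number from compound 2 to compound 4 (0.07 log units; within the scatter). Compound 4 is therefore estimated at 1400 nM, with a likely range from 700 nM to 2800 nM.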

Compound 4, half-maximal inhibitory concentration: 2020 nM
Estimate against measurement, compound 4: 1.4-fold (0.16 log units) below; low and high end bracket the measured number.
By their numbers in this assay, from the lowest: compounds 3, 2 and 4 (each within the scatter of the next); then compound 1.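

In this assay, for the compounds shown here, chloro in place of hydrogen on the aromatic carbon ortho to a large group gives a 1.2-fold higher number from compound 2 to compound 4 (0.09 log units; within the scatter), so a second substituent at this position joins methyl in producing no step that stands clear of the usual scatter. Chloro in place of methyl gives a 1.5-fold higher number from compound 3 to compound 4 (0.17 log units; within the scatter), which is also within the scatter, so hydrogen, methyl and chloro at this carbon cannot be told apart in this read-out. The 2-chlorobenzyl group still separates from the allyl chain, with 2-chlorophenyl in place of vinyl giving a 2.4-fold lower number from compound 1 to compound 4 (0.37 log units; beyond the scatter), so compound 2, compound 3 and compound 4 all sit apart from compound 1 in the same direction, by modest steps.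

The compounds shown leave open whether this carbon tolerates any group at all or only the small ones seen so far, and a methoxy group, an amine or a carboxylic acid in the same place would test that. Nothing available here explains these small differences or the modest gap to compound 1.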